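Swapping the ring on the alkyne arm: thiophene to benzene

The compounds below may be only part of what the source reports. "The series", "measured", "known", "first", "only" and "open" are said of these compounds alone.

Going by the values given here, compound 2 `O=C(O)COc1ccc(Cl)cc1C#Cc1ccc(Cl)s1` gives 183 nM in an assay on CHO cells for displacement of a labelled ligand from prostaglandin D2 receptor 2 (Homo sapiens), read by scintillation counting (a higher number here means a weaker inhibitor, a lower number a stronger inhibitor), the highest of the two numbers measured so far. Its nearest neighbour is compound 1 `Cc1ncccc1C#Cc1cc(Cl)ccc1OCC(=O)O`, which in this assay gives 143 nM; that pair differs only in the ring hanging from the triple-bonded carbon, and the step of a 1.3-fold higher number from compound 1 to compound 2 (0.11 log units; within the scatter) stayed within the scatter. Compound 3 `O=C(O)COc1ccc(Cl)cc1C#Cc1ccc(Cl)cc1` changes the same position again: 4-chlorophenyl in place of 5-chlorothiophen-2-yl on a triple-bonded carbon. Among the compounds with values here, since the one comparable change hardly moved the number, no step beyond the scatter is expected for compound 3, with an estimated 160 nM (range 55 nM to 470 nM), meaning a step of a 1.1-fold lower number from compound 2 to compound 3 (0.06 log units; within the scatter).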

Compound 3, inhibition constant: 60 nM
For compound 3 the middle estimate is 2.7-fold (0.43 log units) above the measured one; the range from low to high includes it.
By their numbers in this assay, from the lowest: compound 3; then compounds 1 and 2 (each within the scatter of the next).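

The position on the triple-bonded carbon does respond to the choice of ring: the change to 4-chlorophenyl gives a 3.1-fold lower number from compound 2 to compound 3 (0.48 log units; beyond the scatter) and also a 2.4-fold lower number from compound 1 to compound 3 (0.38 log units; beyond the scatter). Both steps are modest, but together they set compound 3 apart from the other two compounds, which stay within the scatter of each other. No available evidence explains this difference.

The compounds shown leave open how much of the difference depends on the ring itself and how much on its chlorine. A plain phenyl or a 4-methoxyphenyl on the same carbon would help separate the two.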